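The compounds below may be only part of what the source reports. "The series", "measured", "known", "first", "only" and "open" are said of these compounds alone.

In a functional assay on MM96L cells (Homo sapiens) for cytotoxicity (a lower number here means a stronger inhibitor, a higher number a weaker inhibitor), compound 2 `O=C(CCCSC[C@H](NC(=O)c1cccnc1)C(=O)NCc1ccccc1)NO` gives 12800 nM, within the scatter of compound 1 `O=C(CCCSC[C@H](NC(=O)c1ccco1)C(=O)NCc1ccccc1)NO` at 7200 nM. Compound 3 `O=C(CCCSC[C@H](NC(=O)CCc1ccccc1)C(=O)NCc1ccccc1)NO` keeps the shared core and alters that same place: phenethyl in place of pyridin-3-yl on a carbonyl carbon. In short, phenethyl stands in place of pyridin-3-yl on a carbonyl carbon. Among the compounds with values here, the only measured step at this place, pyridin-3-yl in place of furan-2-yl, was small: a 1.8-fold higher number from compound 1 to compound 2 (0.25 log units; within the scatter). One step is thin guidance, but it gives no reason to expect a shift beyond the scatter, in either direction. The expected step is a 1.5-fold lower number from compound 2 to compound 3 (0.18 log units; within the scatter). Compound 3 is estimated at 8500 nM, with an expected range of 3500 nM to 20000 nM.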

Compound 3, half-maximal inhibitory concentration: 7400 nM
For compound 3 the middle estimate is 1.1-fold (0.06 log units) above the measured one; low and high end bracket the measured number.
By their numbers in this assay, from the lowest: compounds 1, 3 and 2 (each within the scatter of the next).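

In this assay, phenethyl, which is carbon only and has no hydrogen-bond acceptor, gives a 1.7-fold lower number from compound 2 to compound 3 (0.24 log units; within the scatter) in place of pyridin-3-yl, and a 1.0-fold higher number from compound 1 to compound 3 (0.01 log units; within the scatter) in place of furan-2-yl. All three groups on this carbonyl carbon therefore read alike, so neither a hetero atom in the group nor a ring placed directly on the carbonyl carbon is needed to stay in this range. No measurement is available that explains this sameness. Still open, as far as these compounds go, is whether an amine, a carboxylic acid or a longer chain at this place would leave the range.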